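Moving the chlorine around the aryl ring of a phenylpiperazine

The source may report more compounds than this note shows. Statements on the series, on what has been measured and on what is new or still open speak of the compounds shown alone.

Compound 1 `Clc1ccccc1N1CCN(CCCc2ccccc2)CC1` gives 482 nM in an assay for displacement of a labelled ligand from sodium-dependent dopamine transporter (Rattus norvegicus), read by scintillation counting, with a stated time of 120 min; a higher number here means a weaker inhibitor, a lower number a stronger inhibitor.
Compound 2 `Clc1cccc(N2CCN(CCCc3ccccc3)CC2)c1` gives > 10000 nM in this assay, a limit of the assay.

Compound 2 therefore stands at the limit of > 10000 nM in this assay, at which 1 of the 2 values shown sits, not at a number. Going by the values given here, the only measured step, an at least 20-fold higher number from compound 1 to compound 2 (1.31 log units; beyond the scatter), shows that relocating the chlorine can move the value a great deal. Compound 3 `Clc1ccc(N2CCN(CCCc3ccccc3)CC2)cc1` differs from compound 2 by 4-chlorophenyl in place of 3-chlorophenyl on an amine nitrogen in a ring. Among the compounds with values here, no measured step covers this change directly, so the expectation rests on that one large step. Compound 3 is estimated at 6000 nM, in a range from 1500 nM to 30000 nM, which means an expected step of an at least 1.6-fold lower number from compound 2 to compound 3 (0.22 log units; that floor lies within the scatter).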

Compound 3, inhibition constant: 2650 nM
Beside the measured number, compound 3's estimate is 2.3-fold (0.35 log units) above it, and the stated range covers the measured number.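

Moving the chlorine on to give the 4-chlorophenyl group recovers part of what the 3-chlorophenyl group lost in this assay, with an at least 3.7-fold lower number from compound 2 to compound 3 (0.57 log units; beyond the scatter). That step has only a floor, as compound 2 is known only as a limit: the limit of > 10000 nM in this assay, at which 1 of the 3 values shown sits. The 2-chlorophenyl group still gives the strongest binding of the three, with a 5.5-fold higher number from compound 1 to compound 3 (0.74 log units; beyond the scatter).

Still open, as far as these compounds go, is whether fluorine or methoxy in place of the chlorine gives the same order across these three positions. Also open, from the compounds shown here alone, is whether a longer chain on the shared core changes that order.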